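A few compounds are considered here, and "the series" means these few. Any claim that something is new, unique, unknown or untested is made for them only; others in the source may bear on it.

Measured so far:
Compound 1 `Cc1ccc(C(=O)N2CCN(CC(=O)N3CCN(CCCc4c[nH]c5ccc(F)cc45)CC3)CC2)cc1` gives 119000 nM in an ADME assay on SH-SY5Y cells (Homo sapiens) for cytotoxicity, read by MTT assay, with a stated time of 72 h; on this read-out lower numbers stand for stronger inhibition and higher numbers for weaker inhibition.
Compound 2 `O=C(CN1CCN(C(=O)c2ccc(F)cc2)CC1)N1CCN(CCCc2c[nH]c3ccc(F)cc23)CC1` gives 121000 nM in this assay.
Compound 3 `COc1ccc2[nH]cc(CCCN3CCN(C(=O)CN4CCN(C(=O)c5ccc(C)cc5)CC4)CC3)c2c1` reaches only a limit of the assay, > 200000 nM, in this assay.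

Compound 4 `COc1ccc2[nH]cc(CCCN3CCN(C(=O)CN4CCN(C(=O)c5ccc(F)cc5)CC4)CC3)c2c1` has not yet been measured. It differs from compound 3 by fluoro in place of methyl on an aromatic carbon. The same change, at the same place, separates compound 1 from compound 2 (fluoro in place of methyl on an aromatic carbon), where it produced a 1.0-fold higher number from compound 1 to compound 2 (0.01 log units; within the scatter). The cores of the two pairs differ by methoxy in place of fluoro on an aromatic carbon, a change that gave an at least 1.6-fold higher number from compound 1 to compound 3 (0.22 log units; that floor lies within the scatter), with compound 3 sitting at the limit of > 200000 nM in this assay, at which 1 of the 3 values shown sits.

Since the earlier step was flat, compound 4 is expected to stay close to compound 3, with an expected step that the limit leaves unreadable from compound 3 to compound 4. The estimate for compound 4 is 250000 nM, likely between 120000 nM and 600000 nM, and it may again be reported only as a limit.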

Compound 4, half-maximal inhibitory concentration: > 200000 nM
Compound 4 ended at the assay's limit; the forecaster's own chance of this, stated with the estimate: 65%; the middle value lies beyond the limit too.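

In this assay, compound 4 gives > 200000 nM, which is a limit of the assay and not a number. The one step that can be read is methoxy in place of fluoro, an at least 1.6-fold higher number from compound 2 to compound 4 (0.21 log units; that floor lies within the scatter), and setting it beside the same change on the other pair shows matching floors, not matching sizes: the same change on two cores in this assay, an at least 1.6-fold higher number (0.22 log units; that floor lies within the scatter) from compound 1 to compound 3 and an at least 1.6-fold higher number (0.21 log units; that floor lies within the scatter) from compound 2 to compound 4; the limit leaves it open whether they differ The step from 4-methylphenyl to 4-fluorophenyl on the methoxy core cannot be read, so it stays unknown whether the earlier result, a 1.0-fold higher number from compound 1 to compound 2 (0.01 log units; within the scatter), carries over to that core, and the measured values pile up at a single ceiling: the limit of > 200000 nM in this assay, at which 2 of the 4 values shown sit.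

As far as these compounds go, what an amine or a carboxylic acid in place of the fluoro on the 4-fluorophenyl group would give remains open. So does whether any such group would bring the methoxy core to a readable value.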